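This account rests on a few compounds, and the source may have more. Where it says the series, first, only, none or still open, it means among the compounds named here.

In an ADME assay on Vero cells (Chlorocebus sabaeus) for cytotoxicity, with a stated time of 5 days (a higher number here means a weaker inhibitor, a lower number a stronger inhibitor), two compounds have been read so far. Compound 1 (`CC(C)(CO)Nc1nc(N)nc2c1ncn2[C@H]1C[C@H](N=[N+]=[N-])[C@@H](CO)O1`) gives > 100000 nM, which is a limit of the assay and not a number. Compound 2 (`COc1nc(F)nc2c1ncn2[C@H]1C[C@H](N=[N+]=[N-])[C@@H](CO)O1`) gives > 100000 nM, which is likewise a limit. Among the measured compounds shown here, compound 1 therefore stands at the limit of > 100000 nM in this assay, at which 2 of the 2 values shown sit, and no measured step ties it to compound 2.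

Compound 3 (`CC(CO)Nc1nc(N)nc2c1ncn2[C@H]1C[C@H](N=[N+]=[N-])[C@@H](CO)O1`) has not yet been measured in this assay. It departs from compound 1 in one place: hydrogen in place of methyl on a saturated chain carbon bound to a nitrogen on an aromatic ring and two saturated chain carbons. This turns the (1-(hydroxymethyl)-1-methylethyl)amino group into (1-(hydroxymethyl)ethyl)amino, while the shared core stays as it is.

The expectation rests on compound 1, whose reading of > 100000 nM is a limit. No change beyond the scatter is expected, in either direction, and the expected step is a number no higher from compound 1 to compound 3 (the limit leaves the size open). For compound 3 the estimated value is 100000 nM, with an expected range from 40000 nM to 200000 nM.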

Compound 3, half-maximal inhibitory concentration: > 100000 nM
Compound 3 was reported as a limit; the forecaster's own chance of this, stated with the estimate: 80%; the middle value lies on the limit itself.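

In this assay compound 3 reads > 100000 nM, which is a limit and not a number. Among the compounds shown here, compound 1 is also read only as a limit, so no step from compound 1 to compound 3 can be read. Every value shown stands at one reading: the limit of > 100000 nM in this assay, at which 3 of the 3 values shown sit. The compounds shown leave open whether the change from (1-(hydroxymethyl)-1-methylethyl)amino to (1-(hydroxymethyl)ethyl)amino shifts the reading in this assay at all.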